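Aryl swap on the ring nitrogen: compound 2 to compound 3

The source may report more compounds than this note shows. Statements on the series, on what has been measured and on what is new or still open speak of the compounds shown alone.

Compound 2 `CCCOc1ccc(C(=O)Nc2cccc(Nc3cccc(F)c3)n2)cc1` carries a 3-fluorophenyl on a nitrogen on an aromatic ring. In an in vitro assay on HEK-tsA201 cells for antagonist activity at Neuronal acetylcholine receptor; alpha3/beta4 (Homo sapiens), read by fluorescence and calcium flux (a higher number here means a weaker inhibitor, a lower number a stronger inhibitor), compound 2 gives > 100000 nM, which is a limit of the assay and not a number. Compound 1 `CCCCCCNc1cccc(NC(=O)c2ccc(OCCC)cc2)n1` carries a hexyl at that nitrogen instead. In this assay compound 1 gives > 100000 nM, also a limit rather than a number. The change from compound 1 to compound 2 thus reads as a step that the two limits leave unreadable from compound 1 to compound 2, and the whole evidence on the measured steps is the limit of > 100000 nM in this assay, at which 2 of the 2 values shown sit.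

Compound 3 `CCCOc1ccc(C(=O)Nc2cccc(Nc3ccc(OC)cc3)n2)cc1` differs from compound 2 as follows: 4-methoxyphenyl in place of 3-fluorophenyl on a nitrogen on an aromatic ring. Among the measured compounds shown here, no measured step bears on this change in a readable way, and both values on hand sit at a limit, so no direction can be drawn from them. The expectation is that compound 3 stays at or near the limit of this assay, with the step of a number no higher from compound 2 to compound 3 (the limit leaves the size open) expected to be none beyond the scatter. Compound 3 is estimated at 100000 nM in this assay, within 30000 nM to 300000 nM.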

Compound 3, half-maximal inhibitory concentration: > 100000 nM
Compound 3 ended at the assay's limit; the forecaster's own chance of this, stated with the estimate: 85%; the middle value sits exactly at the limit.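

In this assay compound 3 gives > 100000 nM, a limit of the assay and not a number. The steps among compound 1, compound 2 and compound 3 therefore cannot be read, as all three sit at the limit: the limit of > 100000 nM in this assay, at which 3 of the 3 values shown sit.

The compounds shown leave open whether any group on this nitrogen gives a readable value in this assay.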